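Fluoro to Methoxy on the Benzamide Side Chain

This account rests on a few compounds, and the source may have more. Where it says the series, first, only, none or still open, it means among the compounds named here.

Compound 1 `O=C(/C=C/c1ccc(COc2ccccc2)cc1)NO` gives 8400 nM in a functional assay on HepG2 cells (Homo sapiens) for antiproliferative activity, read by CCK-8 assay, with a stated time of 72 h; on this read-out lower numbers stand for stronger inhibition and higher numbers for weaker inhibition. Compound 2 `Nc1ccccc1NC(=O)c1ccc(COc2ccc(F)cc2)cc1` gives 3840 nM and stands lowest of the two numbers shown, with compound 1 the nearest at a gap beyond the usual scatter. Compound 3 `COc1ccc(OCc2ccc(C(=O)Nc3ccccc3N)cc2)cc1` differs from compound 2 by methoxy in place of fluoro on an aromatic carbon. Among the compounds with values here, no measured pair shows this change, so no firm direction is known. Compound 3 is expected to stay close to compound 2, with a step of about a 1.2-fold higher number from compound 2 to compound 3 (0.07 log units; within the scatter) and an estimate of 4500 nM, ranging from 1800 nM to 11000 nM.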

Compound 3, half-maximal inhibitory concentration: 4200 nM
Compound 3: the middle estimate sits 1.1-fold (0.03 log units) above what was measured, and the stated range covers the measured number.
By their numbers in this assay, from the lowest: compounds 2, 3 and 1 (each within the scatter of the next, the first and the last beyond it).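

Within the data shown here, replacing 4-fluorophenyl with 4-methoxyphenyl gives a 1.1-fold higher number from compound 2 to compound 3 (0.04 log units; within the scatter) in this assay, the only measured pair at this position. Here, then, fluoro and methoxy read alike, even though methoxy adds a heavy atom and a hydrogen-bond acceptor. No supporting measurement bears on why the two groups read alike. From the compounds shown here alone, whether an amine, a carboxylic acid or a longer chain at this position would move the number beyond the scatter stays open. So does whether the same change would read alike on the side chain of compound 1.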